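Shifting a Trifluoromethylphenyl Group: What Compound 4 Should Show

This account rests on a few compounds, and the source may have more. Where it says the series, first, only, none or still open, it means among the compounds named here.

Of the compounds shown here, three have so far been tested in a functional assay on A549 cells (Homo sapiens) for inhibition, read by MTT assay, with a stated time of 72 h; a lower number here means a stronger inhibitor, a higher number a weaker inhibitor. Compound 1 `Cc1nc(N(C)C(=O)NC(=O)c2c(F)cccc2F)sc1C(=O)N/N=C/c1cccc(C(F)(F)F)c1` gives 30.3 ug/mL, while compound 2 `Cc1nc(N(C)C(=O)NC(=O)c2c(F)cccc2F)sc1C(=O)N/N=C/c1ccccc1C(F)(F)F` gives 5.43 ug/mL. These two share one core and differ only by 3-(trifluoromethyl)phenyl in place of 2-(trifluoromethyl)phenyl on a carbon with a double bond to nitrogen; that change produced a 5.6-fold higher number from compound 2 to compound 1 (0.75 log units; beyond the scatter). Compound 3 `CN(C(=O)NC(=O)c1ccccc1F)c1nc(C(F)(F)F)c(C(=O)N/N=C/c2ccccc2C(F)(F)F)s1` gives 6.32 ug/mL, a value within the scatter of that of compound 2. How the core of compound 3 differs from the core of compound 2 is not broken down here. Compound 4 `CN(C(=O)NC(=O)c1ccccc1F)c1nc(C(F)(F)F)c(C(=O)N/N=C/c2cccc(C(F)(F)F)c2)s1` has not yet been measured; it differs from compound 3 by 3-(trifluoromethyl)phenyl in place of 2-(trifluoromethyl)phenyl on a carbon with a double bond to nitrogen, the same change as that seen between the first two compounds. Because the earlier version of this change gave a 5.6-fold higher number from compound 2 to compound 1 (0.75 log units; beyond the scatter), a similar weakening is expected here, a 4.7-fold higher number from compound 3 to compound 4 (0.68 log units; beyond the scatter), though one prior example is a thin basis. Compound 4 is therefore estimated at 30 ug/mL, with a likely range from 12 ug/mL to 75 ug/mL.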

Compound 4, half-maximal inhibitory concentration: 19.5 ug/mL
For compound 4 the middle estimate is 1.5-fold (0.19 log units) above the measured one; low and high end bracket the measured number.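

In this assay, putting 3-(trifluoromethyl)phenyl in place of 2-(trifluoromethyl)phenyl again raises the number, with a 3.1-fold higher number from compound 3 to compound 4 (0.49 log units; beyond the scatter). The change therefore weakens inhibition on both cores, and the two steps do not differ in size by more than repeated measurements would allow: the same change on two cores in this assay, a 5.6-fold higher number (0.75 log units; beyond the scatter) from compound 2 to compound 1 and a 3.1-fold higher number (0.49 log units; beyond the scatter) from compound 3 to compound 4, 1.8-fold (0.26 log units) apart, within the scatter of two such steps This supports carrying the change between these two cores, but two examples cannot show that it would hold on other cores, and they do not explain why it weakens inhibition.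

As far as these compounds go, it remains open whether the same shift would appear if a chlorine atom or a methoxy group replaced trifluoromethyl on the phenyl ring. It is also unknown how an amine or a carboxylic acid on that ring would compare.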